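A Longer Link to the Phenyl and Acid Dissociation

The source may report more compounds than this note shows. Statements on the series, on what has been measured and on what is new or still open speak of the compounds shown alone.

Three measured compounds share one core and differ only in the ring carried on a saturated chain carbon bound to an amine nitrogen. Compound 1 `c1ccc(Cc2ccc3c(NCCCNCc4ccco4)ccnc3c2)cc1` carries furan-2-yl there, and in a physicochemical assay for acid dissociation, compound 1 gives 9.47. Compound 2 `COc1ccc(F)cc1CNCCCNc1ccnc2cc(Cc3ccccc3)ccc12` carries 5-fluoro-2-methoxyphenyl, and in this assay compound 2 gives 9.47. Compound 3 `COc1cccc(CNCCCNc2ccnc3cc(Cc4ccccc4)ccc23)c1O` carries 2-hydroxy-3-methoxyphenyl, and in this assay compound 3 gives 9.47. Compound 2 stands level with both neighbours: no change at the digits printed from compound 1 to compound 2 (within the scatter), no change at the digits printed from compound 2 to compound 3 (within the scatter), and likewise no change at the digits printed from compound 1 to compound 3 (within the scatter).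

Compound 4 `COc1ccc(F)cc1CNCCCNc1ccnc2cc(CCc3ccccc3)ccc12` has not yet been measured. Relative to compound 2 the difference is benzyl in place of phenyl on a saturated chain carbon bound to an aromatic carbon. This touches the other side of the core, away from the chain amine. No measured step alters this part of the molecule; the steps that do exist swap the ring on the amine side of the chain and leave the value unmoved, so a swap on the far side of the core gives even less reason to look for a shift. The expected step from compound 2 to compound 4 is therefore no change at the digits printed from compound 2 to compound 4 (within the scatter), nothing beyond the scatter. Compound 4 is expected at 9.47, with a range from 9.17 to 9.77.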

Compound 4, acid dissociation constant: 9.47
Estimate against measurement, compound 4: no gap at the digits printed; the range from low to high includes it.
By their numbers in this assay, from the lowest: compounds 1, 2, 3 and 4 (each within the scatter of the next).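

Until now, every measured step in this assay swapped the ring on the amine side of the chain, so nothing showed whether the other side of the core could move the reading. Compound 4 supplies that first step: benzyl in place of phenyl on a saturated chain carbon bound to an aromatic carbon, which can also be read as benzyl to phenethyl, gives no change at the digits printed from compound 2 to compound 4 (within the scatter), so in this one comparison, adding to the link that carries the phenyl leaves the reading where it was, just as the ring swaps on the amine side did. Nothing available accounts for this result, so the flat reading stands here as an observation without an explanation.

All of this rests on a single step at this place, and both groups involved are plain hydrocarbons, so it says little about what other groups would do there. On these data alone, whether this assay would still give the same reading with a carboxylic acid or an amine attached to the phenyl ring, or with a longer chain than phenethyl, remains open.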